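Replacing Fluoro with Isopropoxy on a Potent Nitrile Analog

A few compounds are considered here, and "the series" means these few. Any claim that something is new, unique, unknown or untested is made for them only; others in the source may bear on it.

Three compounds sharing one core have been examined in a functional assay on CHO cells for inhibition of metabotropic glutamate receptor 5 (Rattus norvegicus), read by FLIPR and calcium flux; on this read-out lower numbers stand for stronger inhibition and higher numbers for weaker inhibition. Compound 1 `Cc1ccc2ccc(-c3cccc(CO)c3)cc2n1` carries a hydroxymethyl group and gives 8700 nM. Compound 2 `Cc1ccc2ccc(-c3cccc(OC(F)(F)F)c3)cc2n1` carries a trifluoromethoxy group instead; in this assay compound 2 reaches only the limit > 10000 nM, which is a limit of the assay and not a number, as noted in the limit of > 10000 nM in this assay, at which 1 of the 3 values shown sits. The step of an at least 1.1-fold higher number from compound 1 to compound 2 (0.06 log units; that floor lies within the scatter) therefore cannot be sized. Compound 3 `Cc1ccc2ccc(-c3cc(F)cc(C#N)c3)cc2n1` bears a fluoro and a cyano group and gives 0.8 nM, the lowest of the two numbers shown, far below compound 1.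

Compound 4 `Cc1ccc2ccc(-c3cc(C#N)cc(OC(C)C)c3)cc2n1` differs from compound 3 as follows: isopropoxy in place of fluoro on an aromatic carbon. Within the data shown here, no measured step touches this pair: the only measured step concerns groups on a ring without a cyano group and ends at a limit, so it offers no guide to the size of the change from fluoro to isopropoxy. Compound 4 keeps the cyano group that accompanies the strong result of compound 3, so a moderate rise in the number is expected rather than a collapse, as the step of a 13-fold higher number from compound 3 to compound 4 (1.10 log units; beyond the scatter) expresses. Compound 4 is accordingly estimated at 10 nM, with a range from 1 nM to 100 nM.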

Compound 4, half-maximal inhibitory concentration: 310 nM
Beside the measured number, compound 4's estimate is 31-fold (1.49 log units) below it; measured number outside the range, above it.
By their numbers in this assay, from the lowest: compound 3; then compound 4; then compound 1. At a limit, above all of these: compound 2.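

In this assay, the exchange of fluoro for isopropoxy gives a 390-fold higher number from compound 3 to compound 4 (2.59 log units; beyond the scatter), a large step and the only one shown at this position, meta to a cyano group. It shows that the cyano group alone does not keep the number low: with the cyano group unchanged, the group at this position still decides much of the result, and fluoro, with its single heavy atom, gives a far lower number here than isopropoxy, with its 4 heavy atoms and its hydrogen-bond acceptor. Nothing measured among these compounds bears on why the step is so large.

On these data alone, the two groups differ both in heavy atoms and in the oxygen that isopropoxy brings, and a single pair cannot separate these differences, so it remains open whether a methoxy group, a chlorine atom or an amine at this position would give a number close to that of compound 3 or that of compound 4. As far as these compounds go, it also remains open whether the same exchange gives a step of this size when a group such as a methyl or a chlorine atom stands in place of the cyano group.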